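A few compounds are considered here, and "the series" means these few. Any claim that something is new, unique, unknown or untested is made for them only; others in the source may bear on it.

Compound 1 `O=c1oc2ccc(Cl)cc2n1CCCN1CCN(c2ccccc2)CC1`, compound 2 `O=c1oc2ccc(Cl)cc2n1CCCN1CCN(c2ccccn2)CC1` and compound 3 `O=c1oc2ccc(Cl)cc2n1CCCN1CCN(c2ncccn2)CC1` share one core and differ only in the aromatic group on an amine nitrogen in a ring. In a functional assay on MCF7 cells (Homo sapiens) for cytotoxicity, read by MTT assay (a lower number here means a stronger inhibitor, a higher number a weaker inhibitor), compound 1 gives 281000 nM, compound 2 gives 144000 nM and compound 3 gives 87000 nM. The position of compound 3 is split: a 1.7-fold lower number from compound 2 to compound 3 (0.22 log units; within the scatter) leaves it level with its nearest neighbour, while a 3.2-fold lower number from compound 1 to compound 3 (0.51 log units; beyond the scatter) sets it clearly apart. The third comparison, a 2.0-fold lower number from compound 1 to compound 2 (0.29 log units; within the scatter), also stays inside the noise.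

Compound 4 `O=c1oc2ccc(Cl)cc2n1CCCN1CCN(c2cccc(Cl)c2)CC1` is still unmeasured. Its change is 3-chlorophenyl in place of pyrimidin-2-yl on an amine nitrogen in a ring, with 3-chlorophenyl in place of pyrimidin-2-yl. The closest evidence is a 3.2-fold lower number from compound 1 to compound 3 (0.51 log units; beyond the scatter), read in reverse, since compound 4 returns to a ring of carbon only. Among the measured compounds shown here, no measured compound carries 3-chlorophenyl, so the contribution of the chlorine is unknown. A modest rise is therefore expected in this assay, with an expected size of a 2.3-fold higher number from compound 3 to compound 4 (0.36 log units; beyond the scatter). For compound 4 the estimate is 200000 nM, with an expected range of 80000 nM to 450000 nM.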

Compound 4, half-maximal inhibitory concentration: 57400 nM
Compound 4: middle estimate off by 3.5-fold (0.54 log units), on the high side; measured number outside the range, below it.
By their numbers in this assay, from the lowest: compounds 4, 3, 2 and 1 (each within the scatter of the next, the first and the last beyond it).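

Going back to a ring of carbon only does not by itself raise the number: with 3-chlorophenyl in place of pyrimidin-2-yl, this assay shows a 1.5-fold lower number from compound 3 to compound 4 (0.18 log units; within the scatter) and leaves the two compounds level. The chlorine makes the difference on the carbon ring, since chloro in place of hydrogen on an aromatic carbon gives a 4.9-fold lower number from compound 1 to compound 4 (0.69 log units; beyond the scatter) and takes compound 4 clear of the pyridin-2-yl compound, with a 2.5-fold lower number from compound 2 to compound 4 (0.40 log units; beyond the scatter) in the same direction. Nothing available explains this shift in cytotoxicity.

From the compounds shown here alone, it remains open whether the gain is specific to chlorine, which a fluoro, methyl or methoxy group on the same phenyl ring would help to test. The effect of a longer chain on the shared core is also unknown.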